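Flipping One Stereocentre in a Lactone Glucosidase Inhibitor

The source may hold more compounds than are shown below. What is called first, only, known or untested is meant among the compounds shown, and "the series" means these compounds.

Of the compounds shown here, three have been tested in an assay on isolated protein for inhibition of Alpha glucosidase (Homo sapiens), read by spectrophotometry, with stated times of 5 min and 15 min; a higher number here means a weaker inhibitor, a lower number a stronger inhibitor. Compound 1, `COC(=O)[C@]1(Cc2ccc3c(c2)C[C@H](C(C)(C)O)O3)OC(=O)C(O)=C1c1ccc(O)cc1`, reaches only the limit of > 400000 nM, so no number is known for it (the limit of > 400000 nM in this assay, at which 1 of the 3 values shown sits). Compound 2, `COC(=O)[C@@]1(O)OC(=O)C(Cc2ccc3c(c2)CCC(C)(C)O3)=C1c1ccc(O)cc1`, gives 10300 nM. Compound 3, `CO[C@H]1OC(=O)C(Cc2ccc(O)c(CC=C(C)C)c2)=C1c1ccc(O)cc1`, gives 8650 nM, a number sitting close to that of compound 2 and within the usual scatter, so neither can be called the stronger.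

Compound 4, `CO[C@@H]1OC(=O)C(Cc2ccc(O)c(CC=C(C)C)c2)=C1c1ccc(O)cc1`, is the untested partner of compound 3: the two compounds have the same atoms and bonds and differ only in configuration as drawn: 1 of 1 stereo elements differ; a stereocentre at a saturated ring carbon is drawn S in compound 3 and R in compound 4. Among the compounds with values here, no measured pair here shows what flipping such a centre does. The step of a 1.2-fold higher number from compound 3 to compound 4 (0.06 log units; within the scatter) is therefore expected to be small, in either direction, not clearly beyond the scatter. Compound 4 is estimated at 10000 nM, with a range from 2500 nM to 40000 nM.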

Compound 4, half-maximal inhibitory concentration: 9980 nM
Compound 4: middle estimate off by 1.0-fold (0.00 log units), on the high side; measured number inside the range.
By their numbers in this assay, from the lowest: compounds 3, 4 and 2 (each within the scatter of the next). At a limit, above all of these: compound 1.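

Within the data shown here, this pair gives the first direct reading of a flip at the saturated ring carbon: going from S to R as drawn gives a 1.2-fold higher number from compound 3 to compound 4 (0.06 log units; within the scatter) in this assay. At this position, with these groups around it, the configuration therefore has no effect that can be told apart from the scatter. The comparison is a clean one, with no other structural change involved: the fact that compounds 3 and 4 differ only in the configuration as drawn

Going by these compounds, whether the flip would stay as silent with an amine or a longer chain on this ring carbon remains open. So does whether it would stay silent with a different side chain on the shared core.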